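The compounds below may be only part of what the source reports. "The series", "measured", "known", "first", "only" and "open" are said of these compounds alone.

The study concerns three measured compounds that share one core and differ only in the aromatic group on an aromatic nitrogen. Compound 1 `Cc1cccc(-n2nncc2CN2C(=O)C3(C(C#N)=C(N)Oc4c3c3nc5ccccc5nc3c3ccccc43)c3ccccc32)c1` carries a 3-methylphenyl there. In an ADME assay on HUVEC cells (Homo sapiens) for antiproliferative activity, read by MTT assay, with a stated time of 48 h (a lower number here means a stronger inhibitor, a higher number a weaker inhibitor), compound 1 gives only a limit, > 50000 nM. Compound 2 `N#CC1=C(N)Oc2c(c3nc4ccccc4nc3c3ccccc23)C12C(=O)N(Cc1cnnn1-c1ccccc1Cl)c1ccccc12` carries a 2-chlorophenyl at that nitrogen. In this assay compound 2 also gives only a limit, > 50000 nM. Compound 3 `N#CC1=C(N)Oc2c(c3nc4ccccc4nc3c3ccccc23)C12C(=O)N(Cc1cnnn1-c1ccc(Br)cc1)c1ccccc12`, with a 4-bromophenyl there, is the starting point of the step followed here. In this assay compound 3 likewise gives only a limit, > 50000 nM. Compound 3 thus stands where every number shown stands, at the limit (the limit of > 50000 nM in this assay, at which 3 of the 3 values shown sit). The steps among the measured compounds, a step that the two limits leave unreadable from compound 1 to compound 2, a step that the two limits leave unreadable from compound 1 to compound 3 and a step that the two limits leave unreadable from compound 2 to compound 3, are not readable in size. Compound 4 `N#CC1=C(N)Oc2c(c3nc4ccccc4nc3c3ccccc23)C12C(=O)N(Cc1cnnn1-c1cc(Cl)ccc1Cl)c1ccccc12` is the compound not yet measured; it differs from compound 3 in one place: 2,5-dichlorophenyl in place of 4-bromophenyl on an aromatic nitrogen. All three measured steps bear on this kind of change, an exchange of the aromatic group on that nitrogen, yet none yields a readable size or direction. One therefore expects no step beyond the scatter, a number no higher from compound 3 to compound 4 (the limit leaves the size open), and expects compound 4 most likely to return a limit again. The estimate for compound 4 in this assay is 50000 nM, between 20000 nM and 120000 nM.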

Compound 4, half-maximal inhibitory concentration: > 50000 nM
Compound 4: only a limit was reported; the forecaster's own chance of this, stated with the estimate: 85%; the middle value lies on the limit itself.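

In this assay compound 4 gives > 50000 nM, which is a limit and not a number. Among the compounds shown here, no step from compound 1, compound 2 or compound 3 to compound 4 can be read in size: the limit of > 50000 nM in this assay, at which 4 of the 4 values shown sit. The compounds shown leave open whether any exchange of the aromatic group on that nitrogen changes the activity in this assay, and in which direction.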